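Nitro for cyano at the weak end of the series

The compounds below may be only part of what the source reports. "The series", "measured", "known", "first", "only" and "open" are said of these compounds alone.

In a functional assay on VCaP cells (Homo sapiens) for antiproliferative activity, read by propidium iodide staining, with a stated time of 96 h (on this read-out lower numbers stand for stronger inhibition and higher numbers for weaker inhibition), compound 3 `CC1(C)C(=O)N(c2ccc(C#N)cc2C(F)(F)F)C(=S)N1c1cccc(S(F)(F)(F)(F)F)c1` gives 100000 nM, the highest of the three numbers and beyond the scatter of both others. Compound 2 `CC(O)(CS(=O)(=O)c1cccc(OC(F)(F)F)c1)C(=O)Nc1ccc(S(F)(F)(F)(F)F)cc1` gives 23700 nM and compound 1 `CC(O)(CSc1ccc(C(F)(F)F)cn1)C(=O)Nc1ccc(S(F)(F)(F)(F)F)cc1` gives 19000 nM. Compound 4 `CC1(C)C(=O)N(c2ccc([N+](=O)[O-])cc2C(F)(F)F)C(=S)N1c1cccc(S(F)(F)(F)(F)F)c1` keeps the core of compound 3 and carries nitro in place of cyano on an aromatic carbon, para to a large group (nitro in place of cyano on an aromatic carbon). Among the measured compounds shown here, no pair of measured compounds differs in one place, so the data hold no direct guide to this change. The expectation rests on compound 3 at 100000 nM. The estimated step of a 1.4-fold lower number from compound 3 to compound 4 (0.15 log units; within the scatter) is expected to stay within the scatter in this assay. For compound 4 the expected value is 70000 nM, with an estimated range of 20000 nM to 130000 nM.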

Compound 4, half-maximal inhibitory concentration: 100000 nM
For compound 4 the middle estimate is 1.4-fold (0.15 log units) below the measured one, and the stated range covers the measured number.
By their numbers in this assay, from the lowest: compounds 1 and 2 (each within the scatter of the next); then compounds 3 and 4 (each within the scatter of the next).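

In this assay, among the compounds shown here, nitro in place of cyano on an aromatic carbon, para to a large group, gives no change at the digits printed from compound 3 to compound 4 (within the scatter) and provides the first one-place comparison. At this position, the exchange of one group for the other leaves compound 4 at the weak end with compound 3, so this change does not lift the series from there. Nothing measured here bears on the reason for this.

From the compounds shown here alone, whether an amine or a carboxylic acid on this carbon would move the number remains open. So does the effect of a change elsewhere on the shared core.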